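Triazole sulfonamide series, two cores, one aryl swap

This account rests on a few compounds, and the source may have more. Where it says the series, first, only, none or still open, it means among the compounds named here.

Measured compounds:
compound 1 `O=c1[nH]cc(S(=O)(=O)Nc2ccccc2-c2cn(-c3ccc(F)cc3)nn2)c(=O)[nH]1`; in a functional assay on SGC-7901 cells (Homo sapiens) for antiproliferative activity, read by MTT assay, with a stated time of 24 h (a higher number here means a weaker inhibitor, a lower number a stronger inhibitor), compound 1 gives only a limit, > 20000 nM.
compound 2 `O=c1[nH]cc(S(=O)(=O)Nc2ccccc2-c2cn(-c3ccccc3Cl)nn2)c(=O)[nH]1`; in this assay compound 2 gives 6520 nM.
compound 3 `O=c1[nH]cc(S(=O)(=O)Nc2cccc(-c3cn(-c4ccc(F)cc4)nn3)c2)c(=O)[nH]1`; in this assay compound 3 gives only a limit, > 20000 nM.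

The cores of compound 1 and compound 3 are built from the same atoms joined differently; that difference between the two cores is not broken down here. Within the core of compound 1, the change 2-chlorophenyl in place of 4-fluorophenyl on an aromatic nitrogen gives an at least 3.0-fold lower number from compound 1 to compound 2 (0.48 log units; beyond the scatter), and the size is known only as a bound because of the limit of > 20000 nM in this assay, at which 2 of the 3 values shown sit.

Compound 4 `O=c1[nH]cc(S(=O)(=O)Nc2cccc(-c3cn(-c4ccccc4Cl)nn3)c2)c(=O)[nH]1` carries the same kind of change on the core of compound 3, (2-chlorophenyl in place of 4-fluorophenyl on an aromatic nitrogen). Among the measured compounds shown here, since compound 3 sits at a limit, a step of about an at least 1.3-fold lower number from compound 3 to compound 4 (0.12 log units; that floor lies within the scatter) is expected for compound 4, resting on the step from compound 1 to compound 2 as the only measured precedent. Compound 4 is estimated at 15000 nM, within 5000 nM to 40000 nM, with a limit-only result remaining quite possible.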

Compound 4, half-maximal inhibitory concentration: 3010 nM
Beside the measured number, compound 4's estimate is 5.0-fold (0.70 log units) above it; measured number outside the range, below it.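

In this assay the change to 2-chlorophenyl from 4-fluorophenyl also lowers the number on the second core, with an at least 6.6-fold lower number from compound 3 to compound 4 (0.82 log units; beyond the scatter), so the direction of the step holds on both cores shown. Whether its size carries over stays unsettled, since both steps start from a limit: the same change on two cores in this assay, an at least 3.0-fold lower number (0.48 log units; beyond the scatter) from compound 1 to compound 2 and an at least 6.6-fold lower number (0.82 log units; beyond the scatter) from compound 3 to compound 4; the limit leaves it open whether they differ Neither step therefore has a measured size, only a floor, and two cores cannot establish a rule for the series: the limit of > 20000 nM in this assay, at which 2 of the 4 values shown sit.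

The change from 4-fluorophenyl to 2-chlorophenyl alters both the halogen and its place on the phenyl ring, so the compounds shown do not separate these two parts. Also open, on these data alone, is whether a methoxy group or an amine on that phenyl ring would follow the same direction.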